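Aryl swap on the acetylated saturated ring carbon

The compounds below may be only part of what the source reports. "The series", "measured", "known", "first", "only" and "open" are said of these compounds alone.

compound 1 `COc1ccc(OC)c(C2CC(c3cc(OC)c(OC)c(OC)c3)=NN2C(C)=O)c1`: only a limit, > 100000 nM
compound 2 `COc1ccc(C2CC(c3cc(OC)c(OC)c(OC)c3)=NN2C(C)=O)cc1O`: only a limit, > 100000 nM
compound 3 `COc1ccc(C2CC(c3cc(OC)c(OC)c(OC)c3)=NN2)cc1O`: 2100 nM

In a functional assay on B16 cells (Mus musculus) for cytotoxicity, read by MTT assay, with a stated time of 72 h (a lower number here means a stronger inhibitor, a higher number a weaker inhibitor), compound 2 gives only a limit, > 100000 nM, so it has no measured number to stand on. Compound 1 sits at the same limit, > 100000 nM. Compound 3 is the only one of the three with a number, 2100 nM. The step between the acetylated pair is unreadable, a step that the two limits leave unreadable from compound 1 to compound 2, because the limit of > 100000 nM in this assay, at which 2 of the 3 values shown sit, holds both ends. Removal of the acetyl is the one readable step, an at least 47-fold lower number from compound 2 to compound 3 (1.67 log units; beyond the scatter).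

Compound 4 `COc1ccccc1C1CC(c2cc(OC)c(OC)c(OC)c2)=NN1C(C)=O` keeps the acetyl of compound 2 and differs only in the aryl: 2-methoxyphenyl in place of 3-hydroxy-4-methoxyphenyl on a saturated ring carbon. The step that bears on it is the earlier aryl swap on the same carbon, which stayed at the limit from compound 1 to compound 2; no aryl change with the acetyl retained has yet given a number. Compound 4 is therefore expected to remain at or near the limit, with no step beyond the scatter, a number no higher from compound 2 to compound 4 (the limit leaves the size open). The estimate for compound 4 is 100000 nM, within 30000 nM to 300000 nM, most likely reported as a limit again.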

Compound 4, half-maximal inhibitory concentration: > 100000 nM
Compound 4 was reported as a limit (the forecaster's own chance of this, stated with the estimate: 75%); the middle value sits exactly at the limit.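

In this assay compound 4 gives > 100000 nM as a limit and not a number. The steps linking compound 4 to compound 1 and compound 2 cannot be read because all three sit at one limit: the limit of > 100000 nM in this assay, at which 3 of the 4 values shown sit. The compounds shown leave open whether any aryl change matters while the acetyl is kept; only compound 3, which lacks the acetyl, has a number.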